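Working notes: from compound 2 to compound 4

A few compounds are considered here, and "the series" means these few. Any claim that something is new, unique, unknown or untested is made for them only; others in the source may bear on it.

Measured in a functional assay on MCF7 cells (Homo sapiens) for antiproliferative activity, read by MTT assay, with a stated time of 48 h; a lower number here means a stronger inhibitor, a higher number a weaker inhibitor
- compound 1 `CCN(CC)Cc1ccc2c(c1O)-c1ccc(cc1O)CCc1ccc(O)c(c1)Oc1ccc(cc1)CC2` gives 7590 nM
- compound 2 `Oc1ccc2cc1Oc1ccc(cc1)CCc1ccc(CN3CCCCC3)c(O)c1-c1ccc(cc1O)CC2` gives 5070 nM
- compound 3 `Oc1ccc2cc1Oc1ccc(cc1)CCc1ccc(CN3CCN(Cc4ccccc4)CC3)c(O)c1-c1ccc(cc1O)CC2` gives > 20000 nM (a limit of the assay, not a number)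

Compound 2 stands within the scatter of compound 1, the step being a 1.5-fold lower number from compound 1 to compound 2 (0.18 log units; within the scatter). The only other result is the limit of > 20000 nM in this assay, at which 1 of the 3 values shown sits, and it belongs to compound 3.

The next change leads to compound 4 `CCCCN(CCCC)Cc1ccc2c(c1O)-c1ccc(cc1O)CCc1ccc(O)c(c1)Oc1ccc(cc1)CC2` and reads (dibutylamino in place of piperidin-1-yl on a saturated chain carbon bound to an aromatic carbon), that is, dibutylamino in place of piperidin-1-yl on a saturated chain carbon bound to an aromatic carbon. Within the data shown here, one measured step bears on it directly: a 1.5-fold lower number from compound 1 to compound 2 (0.18 log units; within the scatter), an exchange of the same kind that stayed within the scatter. As far as these compounds go, on that single step, no change beyond the scatter is expected in this assay, though the direction stays open and the range is kept wide on the upper side. The estimated step is a 1.4-fold higher number from compound 2 to compound 4 (0.14 log units; within the scatter). For compound 4 the expected value is 7000 nM, with an estimated range from 3000 nM to 16000 nM.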

Compound 4, half-maximal inhibitory concentration: > 20000 nM
Compound 4 was reported as a limit; the forecaster's own chance of this, stated with the estimate: 10%; middle value at least 2.8-fold (0.45 log units) away from the limit.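

On the saturated chain carbon bound to an aromatic carbon, the amine exchange now has a visible effect in this assay: dibutylamino in place of piperidin-1-yl gives an at least 3.9-fold higher number from compound 2 to compound 4 (0.59 log units; beyond the scatter), and dibutylamino in place of diethylamino gives an at least 2.6-fold higher number from compound 1 to compound 4 (0.42 log units; beyond the scatter), whereas piperidin-1-yl in place of diethylamino stayed within the scatter. Compound 4 is reported as a limit of the assay and not a number, so both steps give only a minimum size: the limit of > 20000 nM in this assay, at which 2 of the 4 values shown sit. This place therefore does not accept every amine, since compound 1 and compound 2 give measured values while compound 3 and compound 4 do not.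

Whether the loss follows the larger heavy-atom count of dibutylamino or the open chains themselves remains unresolved. Dipropylamino or morpholin-4-yl at this place would bear on that question.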